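The source may hold more compounds than are shown below. What is called first, only, known or untested is meant among the compounds shown, and "the series" means these compounds.

Working notes on the series. Three compounds carry numbers in a functional assay on MCF7 cells (Homo sapiens) for inhibition, read by MTT assay, with a stated time of 72 h; on this read-out lower numbers stand for stronger inhibition and higher numbers for weaker inhibition. Compound 1 `Cc1cc(Nc2cc(-c3ccccc3)[nH]n2)n2nc(SCc3c(Cl)cccc3Cl)nc2n1` gives 3230 nM in this assay. Compound 2 `Cc1cc(Nc2cc(-c3ccc(Cl)cc3)[nH]n2)n2nc(SCc3ccc(Br)cc3)nc2n1` gives 3620 nM in this assay, and the two values lie within the scatter of each other, so nothing separates them. Compound 3 `Cc1cc(Nc2ccn(Cc3nc(C)c4ccccc4n3)n2)n2nc(SCc3ccc(Br)cc3)nc2n1` gives 1430 nM in this assay, a lower number than compound 1 and beyond the scatter, which leaves compound 1 as the second highest of the three numbers.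

Compound 4 `Cc1cc(Nc2cc(-c3ccccc3)[nH]n2)n2nc(SCCc3ccccc3)nc2n1` has not been measured. Against compound 1 it shows one difference: benzyl in place of 2,6-dichlorophenyl on a saturated chain carbon bound to a sulfur. The ring that enters carries no chlorine and sits one bond further from the sulfur, so the sulfanyl chain becomes phenethylsulfanyl. Within the data shown here, no measured pair in the set mirrors this change, so there is no step to lean on. The expectation for compound 4 is a step of a 1.4-fold higher number from compound 1 to compound 4 (0.14 log units; within the scatter) toward a slightly higher number, one that may well stay within the scatter. Compound 4 is estimated at 4500 nM in this assay, with a range from 1800 nM to 11000 nM.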

Compound 4, half-maximal inhibitory concentration: 2700 nM
Estimate against measurement, compound 4: 1.7-fold (0.22 log units) above; measured number inside the range.
By their numbers in this assay, from the lowest: compounds 3, 4, 1 and 2 (each within the scatter of the next, the first and the last beyond it).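

In this assay, among these compounds, the change at this position gives a 1.2-fold lower number from compound 1 to compound 4 (0.08 log units; within the scatter), the first step between compounds that differ in one place. On the saturated chain carbon bound to a sulfur, (2,6-dichlorobenzyl)sulfanyl and phenethylsulfanyl therefore cannot be told apart on this read-out, even though the ring loses its chlorines and sits one bond further from the sulfur. No measured property bears on this result.

Among the compounds shown here, the single step joins the loss of the chlorines and the added bond, so the share of each stays open, as does whether the flat result holds when the 2,6-dichlorobenzyl group gives way to a longer chain such as 3-phenylpropyl. A chain ending in an amine or a carboxylic acid in this place also remains an open question.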